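Swapping methoxy for fluoro on a growth inhibitor

The source may report more compounds than this note shows. Statements on the series, on what has been measured and on what is new or still open speak of the compounds shown alone.

- compound 1 `COc1ccccc1/C=C(\C(=O)c1ccc(Cl)cc1)S(=O)(=O)Cc1ccc(Cl)c(Cl)c1` gives 1000 nM
- compound 2 `COc1ccccc1/C=C(\C(=O)c1ccc(Cl)cc1)S(=O)(=O)c1ccc(C)cc1` gives 1000 nM

In a functional assay on DU-145 cells (Homo sapiens) for inhibition, read by trypan blue exclusion, with a stated time of 96 h (a lower number here means a stronger inhibitor of growth, a higher number a weaker inhibitor of growth), compound 2 gives 1000 nM, level with compound 1. The next structure, compound 3 `Cc1ccc(S(=O)(=O)/C(=C/c2ccccc2F)C(=O)c2ccc(Cl)cc2)cc1`, carries fluoro in place of methoxy on an aromatic carbon, ortho to a large group: fluoro in place of methoxy on an aromatic carbon. Within the data shown here, only one measured step exists, no change at the digits printed from compound 1 to compound 2 (within the scatter), and it replaced 3,4-dichlorobenzyl with 4-methylphenyl on a sulfonyl sulfur. That is a different place from the one changing now, so it bears on this change only indirectly. Among the measured compounds shown here, no measured compound shows what swapping methoxy for fluoro does, so no direction can be favoured and a step beyond the scatter is not expected. The expected change is no change at the digits printed from compound 2 to compound 3 (within the scatter). For compound 3 the estimated value is 1000 nM, with an expected range from 300 nM to 3500 nM.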

Compound 3, concentration for 50% growth inhibition: 2500 nM
Beside the measured number, compound 3's estimate is 2.5-fold (0.40 log units) below it, and the stated range covers the measured number.
By their numbers in this assay, from the lowest: compounds 1 and 2 (each within the scatter of the next); then compound 3.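

In this assay, going from 2-methoxyphenyl to 2-fluorophenyl gives a 2.5-fold higher number from compound 2 to compound 3 (0.40 log units; beyond the scatter) and so leaves the methoxy compound the stronger growth inhibitor of this pair. The step is modest, but unlike the earlier change on the sulfonyl sulfur, it lies beyond the scatter, which shows that the assay can register a change at this ring position. Nothing given here explains why the fluoro compound is weaker, so the shift stands as an observation without a known cause.

With only methoxy and fluoro shown at this position, it remains open how a hydroxyl, an amine or a longer chain such as ethoxy would read there. Also open, going by these compounds, is whether the same swap would give a similar step with 3,4-dichlorobenzyl on the sulfonyl sulfur, as in compound 1.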